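From methoxy to 2-hydroxy-1-(hydroxymethyl)ethyl on compound 1

The compounds below may be only part of what the source reports. "The series", "measured", "known", "first", "only" and "open" are said of these compounds alone.

In a physicochemical assay for lipophilicity, at pH 7.4 (a lower number here means a more polar compound, a higher number a more lipophilic compound), compound 1 `COc1ccc2c(c1)C=CN(C)C(=O)[C@@H]2C` gives 4.3. Compound 2 `COCCOc1ccc2c(c1)C=CN(C)C(=O)[C@@H]2C`, at 4, stands within the scatter of it, whereas compound 3 `CC1C(=O)N(C)C=Cc2cc(OCC(C)(C)O)ccc21`, at 3.6, lies lower, beyond the scatter. The unmeasured compound 4 `C[C@H]1C(=O)N(C)C=Cc2cc(C(CO)CO)ccc21` differs from compound 1 as follows: 2-hydroxy-1-(hydroxymethyl)ethyl in place of methoxy on an aromatic carbon. For the measured compounds named here, the only measured step, a number 0.30 log units lower from compound 1 to compound 2 (within the scatter), adds methoxymethyl on a saturated chain carbon and bears only weakly on this change. Compound 3, which carries a hydroxyl group, is the closer guide, with its 3.6. A fall beyond the scatter, larger than the gap seen for compound 3, is expected here, estimated as a number 1.40 log units lower from compound 1 to compound 4 (beyond the scatter). For compound 4 the expected value is 2.9, with an estimated range of 2.3 to 3.4.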

Compound 4, distribution coefficient: 1.2
Compound 4: middle estimate off by 1.70 log units, on the high side, and the stated range ends above it.
By their numbers in this assay, from the lowest: compound 4; then compound 3; then compounds 2 and 1 (each within the scatter of the next).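

In this assay, putting 2-hydroxy-1-(hydroxymethyl)ethyl in place of methoxy on this aromatic carbon gives a number 3.10 log units lower from compound 1 to compound 4 (beyond the scatter), a far larger step than the one earlier step shown. Starting instead from 2-methoxyethoxy, the same group gives a number 2.80 log units lower from compound 2 to compound 4 (beyond the scatter), so the large fall appears from both starting groups. Nothing available explains the size of this fall.

The compounds shown leave open how a single hydroxymethyl group would read at this position. They also leave open where an amine or a carboxylic acid on this carbon would fall.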